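A Methyl on the Piperidine Ring of Compound 1

The source may hold more compounds than are shown below. What is called first, only, known or untested is meant among the compounds shown, and "the series" means these compounds.

In a functional assay on MDA-MB-231 cells (Homo sapiens) for cytotoxicity, read by MTT assay, with a stated time of 72 h (a higher number here means a weaker inhibitor, a lower number a stronger inhibitor), compound 1 `COc1cc2c(Oc3ccc(NC(=O)N/N=C/c4ccc(Cl)cc4Cl)cc3F)ccnc2cc1OCCCN1CCCCC1` gives 750 nM.
In this assay compound 2 `COc1cc2c(Oc3ccc(NC(=O)N/N=C/c4ccc(O)cc4)cc3F)ccnc2cc1OCCCN1CCCCC1` gives 790 nM.

Compound 1 carries the lower of the two numbers, but only by a 1.1-fold higher number from compound 1 to compound 2 (0.02 log units; within the scatter), so the two sit within the scatter of each other. Compound 3 `COc1cc2c(Oc3ccc(NC(=O)N/N=C/c4ccc(Cl)cc4Cl)cc3F)ccnc2cc1OCCCN1CCC(C)CC1` differs from compound 1 by methyl in place of hydrogen on a saturated ring carbon. Among the measured compounds shown here, no measured step touches that saturated ring; the single step known concerns the aryl group at the far end of the molecule and stayed within the scatter. Compound 3 is therefore expected to give 700 nM, with a range of 300 nM to 1600 nM, a step of a 1.1-fold lower number from compound 1 to compound 3 (0.03 log units; within the scatter).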

Compound 3, half-maximal inhibitory concentration: 910 nM
Compound 3: middle estimate off by 1.3-fold (0.11 log units), on the low side; low and high end bracket the measured number.
By their numbers in this assay, from the lowest: compounds 1, 2 and 3 (each within the scatter of the next).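

Methyl in place of hydrogen on this saturated ring carbon, turning piperidin-1-yl into 4-methylpiperidin-1-yl, gives in this assay a 1.2-fold higher number from compound 1 to compound 3 (0.08 log units; within the scatter). Among the compounds shown here, this is the first measured step at the saturated ring, and it shows that this position accepts a single methyl with compound 1 and compound 3 staying within the scatter of each other. No independent evidence bears on this result.

As far as these compounds go, whether a hydroxyl or a phenyl on the same ring carbon would also stay within the scatter remains open. So does the effect of a morpholine in place of the piperidine.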